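Extending a Thioether Side Chain: An Estimate for Compound 3

The source may report more compounds than this note shows. Statements on the series, on what has been measured and on what is new or still open speak of the compounds shown alone.

Measured so far:
- compound 1, `COc1ccc(-n2c(S)nnc2-c2cc(OC)c(OC)c(OC)c2)cc1`, gives 57500 nM
- compound 2, `CCSc1nnc(-c2cc(OC)c(OC)c(OC)c2)n1-c1ccc(N(C)C)cc1`, gives > 60000 nM

Both compounds were tested in a functional assay on HepG2 cells (Homo sapiens) for inhibition, read by MTT assay, with a stated time of 48 h; a higher number here means a weaker inhibitor, a lower number a stronger inhibitor. Compound 1 gives a weak reading of 57500 nM. For compound 2 the result of > 60000 nM is not a number but a limit of the assay, as described by the limit of > 60000 nM in this assay, at which 1 of the 2 values shown sits. Compound 2 therefore stands at the very weak end of the two values shown, and nothing closer can be said about where it really lies.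

Compound 3, `COc1cc(-c2nnc(SCC(=O)Nc3ccc(Cl)cc3)n2-c2ccc(N(C)C)cc2)cc(OC)c1OC`, has not yet been measured in this assay. It differs from compound 2 in one place: (4-chlorophenyl)carbamoyl in place of methyl on a saturated chain carbon bound to a sulfur. Among the compounds with values here, no pair of measured compounds differs in a single place, so there is no measured step to lean on, and the only guide is that compound 2 itself sits at a limit.

The step from compound 2 to compound 3 is expected to be small, an at least 1.3-fold lower number from compound 2 to compound 3 (0.12 log units; that floor lies within the scatter), and not clearly beyond the scatter in either direction. Compound 3 is therefore estimated at 45000 nM, with a likely range from 12000 nM to 150000 nM.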

Compound 3, half-maximal inhibitory concentration: > 60000 nM
Compound 3: a limit, no number; the forecaster's own chance of this, stated with the estimate: 45%; middle value at least 1.3-fold (0.12 log units) away from the limit.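

In this assay compound 2 and compound 3 both end at a limit of the assay rather than a number, so no step between them can be read: the limit of > 60000 nM in this assay, at which 2 of the 3 values shown sit.

The compounds shown leave open how far either one lies past that limit, and whether (4-chlorophenyl)carbamoyl in place of methyl changes the reading at all.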